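The source may report more compounds than this note shows. Statements on the series, on what has been measured and on what is new or still open speak of the compounds shown alone.

Measured in an ADME assay on NCI-H460 cells (Homo sapiens) for cytotoxicity, read by MTT assay; a lower number here means a stronger inhibitor, a higher number a weaker inhibitor:
- compound 1 `COc1cc(O)c(C(/C=C/CC(O)CCc2ccccc2)c2ccc(O)cc2)c(O)c1C(=O)/C=C/c1ccc(O)cc1`: 45700 nM
- compound 2 `COc1cc(O)c(C(/C=C/CC(O)CCc2ccc(O)cc2)c2ccc(O)cc2)c(O)c1C(=O)/C=C/c1ccccc1`: 47400 nM

Compound 2 and compound 1 lie within the scatter of each other. Compound 3 `COc1cc(O)c(C(/C=C/CC(O)CCc2ccccc2)c2ccc(O)cc2)c(O)c1C(=O)/C=C/c1ccccc1` departs from compound 2 by hydrogen in place of hydroxy on an aromatic carbon, with hydrogen in place of hydroxy on an aromatic carbon, turning 2-(4-hydroxyphenyl)ethyl into phenethyl. Among the measured compounds shown here, no measured pair isolates this change. Compound 1 already carries phenethyl and gives 45700 nM, so no shift beyond the scatter is expected in this assay, and neither direction is favoured. The expected outcome is a 1.1-fold lower number from compound 2 to compound 3 (0.05 log units; within the scatter). Compound 3 is estimated at 42000 nM, with an expected range of 20000 nM to 85000 nM.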

Compound 3, half-maximal inhibitory concentration: 39800 nM
Compound 3: middle estimate off by 1.1-fold (0.02 log units), on the high side; the range from low to high includes it.
By their numbers in this assay, from the lowest: compounds 3, 1 and 2 (each within the scatter of the next).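

In this assay, hydrogen in place of hydroxy, turning 2-(4-hydroxyphenyl)ethyl into phenethyl, now has a measured pair, with a 1.2-fold lower number from compound 2 to compound 3 (0.08 log units; within the scatter) as its step. The same exchange on a different aromatic carbon gives a 1.1-fold lower number from compound 1 to compound 3 (0.06 log units; within the scatter) as its step, so at neither site does losing the hydroxy move the number beyond the scatter. Nothing available explains why these hydroxy groups leave the number unmoved.

Going by these compounds, whether an amine, a carboxylic acid or fluorine on the phenethyl ring would shift the number remains open. So does whether any change to the shared core would.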